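Pyrrolidinyl to piperazinyl swap and cell cytotoxicity

The source may report more compounds than this note shows. Statements on the series, on what has been measured and on what is new or still open speak of the compounds shown alone.

Of the compounds shown here, three have been measured in a functional assay on V79 cells (Cricetulus griseus) for cytotoxicity, read by colony formation; on this read-out lower numbers stand for stronger inhibition and higher numbers for weaker inhibition. Compound 1 `CNCC1(C)CCN(c2c(F)cc3c(=O)c(C(=O)O)cn(C4CC4)c3c2C(F)(F)F)C1` gives 230 ug/mL. Compound 3 `O=C(O)c1cn(C2CC2)c2c(C(F)(F)F)c(N3CCNCC3)c(F)cc2c1=O` gives 1650 ug/mL, and compound 2 `CNCC1(C)CCN(c2nc3c(cc2F)c(=O)c(C(=O)O)cn3C2CC2)C1` gives 58 ug/mL, the lowest of the three numbers, with both steps to the other compounds beyond the scatter. The step of a 7.2-fold higher number from compound 1 to compound 3 (0.86 log units; beyond the scatter) belongs to the change (piperazin-1-yl in place of 3-methyl-3-((methylamino)methyl)pyrrolidin-1-yl on an aromatic carbon).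

Compound 4 `O=C(O)c1cn(C2CC2)c2nc(N3CCNCC3)c(F)cc2c1=O` is not yet measured. It arises from compound 2 by the same kind of change, (piperazin-1-yl in place of 3-methyl-3-((methylamino)methyl)pyrrolidin-1-yl on an aromatic carbon). The difference between the core of compound 2 and the core of compound 1 is not broken down here. The surroundings of the place also differ: in compound 1 the change is made on a six-membered aromatic ring of carbon only, ortho to a trifluoromethyl group, whereas in compound 2 it is made on a six-membered aromatic ring with 1 nitrogen, next to the ring nitrogen.

Going from compound 2 to compound 4, a step of about a 6.9-fold higher number from compound 2 to compound 4 (0.84 log units; beyond the scatter) in this assay is expected, resting on the measured step of a 7.2-fold higher number from compound 1 to compound 3 (0.86 log units; beyond the scatter) and allowing for the different core. Compound 4 is thus estimated at 400 ug/mL, expected to lie between 150 ug/mL and 1100 ug/mL.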

Compound 4, half-maximal inhibitory concentration: 120 ug/mL
Beside the measured number, compound 4's estimate is 3.3-fold (0.52 log units) above it; the whole stated range lies above it.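

In this assay, piperazin-1-yl in place of 3-methyl-3-((methylamino)methyl)pyrrolidin-1-yl again gives a higher number on the second core, with a 2.1-fold higher number from compound 2 to compound 4 (0.32 log units; beyond the scatter), but the size of the step does not carry over: the same change on two cores in this assay, a 7.2-fold higher number (0.86 log units; beyond the scatter) from compound 1 to compound 3 and a 2.1-fold higher number (0.32 log units; beyond the scatter) from compound 2 to compound 4, 3.5-fold (0.54 log units) apart, beyond the scatter of two such steps The direction of the change is therefore shared by these two pairs, while a step measured on one core cannot be applied as a number to the other. Two pairs give no general rule, and they do not show which of the differences between the core of compound 1 and the core of compound 2 goes with the smaller step, since the trifluoromethyl group and the ring nitrogen are not separated here.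

The compounds shown leave open whether a core with only one of these two differences would give a step nearer to the first or the second. They also leave open whether another amine, such as morpholine or a piperazine bearing a methyl group, would follow the same direction on both cores.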